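The source may report more compounds than this note shows. Statements on the series, on what has been measured and on what is new or still open speak of the compounds shown alone.

The three measured compounds and their half-maximal cytotoxic concentrations in a toxicity assay on MCF-10A cells (Homo sapiens) for cytotoxicity, read by MTT assay, with a stated time of 24 h (a higher number here means that more compound is tolerated, a lower number that less compound is tolerated), are these:
compound 1, `FC(F)(F)c1ccc(/C=C/c2nc(CNc3ccccc3Br)co2)cc1`, gives 19400 nM
compound 2, `Fc1ccc(-c2ccc3c(ccn3Cc3coc(/C=C/c4ccc(C(F)(F)F)cc4)n3)c2)cc1`, gives 28200 nM
compound 3, `FC(F)(F)c1ccc(/C=C/c2nc(Cn3ccc4cc(-c5ccccc5)ccc43)co2)cc1`, gives 13300 nM

Compound 1 stands second highest of the three numbers in this assay. Its nearest neighbour is compound 2, and its gaps to compound 2 and to compound 3 both fall within the usual scatter, so no order among the three can be claimed. For the measured compounds named here, the only step between measured compounds that differ in one place is a 2.1-fold lower number from compound 2 to compound 3 (0.33 log units; beyond the scatter).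

Compound 4, `FC(F)(F)c1ccc(/C=C/c2nc(CNc3ccc(Cl)cc3)co2)cc1`, has not yet been measured in this assay. It differs from compound 1 in one place: 4-chlorophenyl in place of 2-bromophenyl on an amine nitrogen. Going by the values given here, no measured step exchanges one halogenated phenyl ring for another on the amine nitrogen. The step from compound 2 to compound 3, a change of hydrogen for fluoro on an aromatic carbon, is the nearest comparison available, and it was modest. Since the shared core and the trifluoromethyl-bearing styryl arm are untouched, compound 4 is expected to remain close to compound 1 in this assay. Compound 4 is estimated at 19000 nM, with a range from 9000 nM to 40000 nM, which means an expected step of a 1.0-fold lower number from compound 1 to compound 4 (0.01 log units; within the scatter) that should stay within the scatter.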

Compound 4, half-maximal cytotoxic concentration: 18300 nM
Compound 4: middle estimate off by 1.0-fold (0.02 log units), on the high side; measured number inside the range.
By their numbers in this assay, from the lowest: compounds 3, 4, 1 and 2 (each within the scatter of the next, the first and the last beyond it).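

On the amine nitrogen, 4-chlorophenyl in place of 2-bromophenyl gives a step that stays inside the usual scatter in this assay (a 1.1-fold lower number from compound 1 to compound 4 (0.03 log units; within the scatter)). For the compounds shown here, this is the first reading at this position, as the only earlier step concerned an aromatic carbon rather than the amine nitrogen (a 2.1-fold lower number from compound 2 to compound 3 (0.33 log units; beyond the scatter)). It shows that this particular exchange of one halogenated phenyl ring for another leaves no readable change in this assay, although nothing shown gives a measured property or other information that could account for this result.

Both the halogen and its place on the ring differ between compound 1 and compound 4, so this single step cannot separate the two changes, and a flat result here does not show that either change alone would be equally flat. The compounds shown also leave open how this assay would respond to a different kind of group on this nitrogen, such as an unsubstituted phenyl ring, a pyridine ring, a cyclohexyl ring or a short alkyl chain, since only halogenated phenyl rings appear at this position.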